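Sulfanyl in Place of Benzylamino on the Shared Core

The source may hold more compounds than are shown below. What is called first, only, known or untested is meant among the compounds shown, and "the series" means these compounds.

Measured compounds:
compound 1, `COc1cc(CNc2nc3cc(N)cc(N)c3nc2-c2ccccc2)cc(OC)c1OC`: 43700 nM
compound 2, `Nc1cc(N)c2nc(-c3ccccc3)c(NCc3ccc(F)cc3)nc2c1`: < 100000 nM
compound 3, `COc1ccc(CNc2nc3cc(N)cc(N)c3nc2-c2ccccc2)cc1`: < 100000 nM

In a functional assay on HT-29 cells (Homo sapiens) for inhibition, read by sulforhodamine B assay, with a stated time of 48 h (on this read-out lower numbers stand for higher toxicity in this test and higher numbers for lower toxicity in this test), compound 1 gives 43700 nM. For compound 2 the result is only a limit of the assay, < 100000 nM. For compound 3 the result is likewise only a limit, < 100000 nM. The step that the two limits leave unreadable from compound 2 to compound 3 cannot be read because of the limit of < 100000 nM in this assay, at which 2 of the 3 values shown sit. For the measured compounds named here, compound 2 therefore stands at that limit, with no number of its own, and the one value that is a number, that of compound 1, sits on the other side of it.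

Compound 4, `Nc1cc(N)c2nc(-c3ccccc3)c(Sc3ccc(F)cc3)nc2c1`, differs from compound 2 by (4-fluorophenyl)sulfanyl in place of (4-fluorobenzyl)amino on an aromatic carbon. Going by the values given here, none of the measured steps bears on this change: the only step among the measured compounds, that from compound 2 to compound 3, concerns a different position and is unreadable. With compound 2 known only as a limit, the step that the limit leaves unreadable from compound 2 to compound 4 is an expectation without a measured anchor, and no direction beyond the scatter is expected. Compound 4 is thus estimated to give 40000 nM in this assay, within a range of 8000 nM to 100000 nM.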

Compound 4, concentration lethal to 50% of the cells: < 100000 nM
Compound 4 gave a limit, no number; the forecaster's own chance of this, stated with the estimate: 40%; the middle value does not contradict the limit.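

In this assay compound 4 gives < 100000 nM, which is a limit of the assay and not a number. Compound 2 is also known only as a limit, so no step between compound 2 and compound 4 can be read: the limit of < 100000 nM in this assay, at which 3 of the 4 values shown sit.

The compounds shown leave open how (4-fluorophenyl)sulfanyl in place of (4-fluorobenzyl)amino shifts the value on the shared core.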